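Oral Tail Flick Response of Purine Glycinamide Esters

The compounds below may be only part of what the source reports. "The series", "measured", "known", "first", "only" and "open" are said of these compounds alone.

Compound 1 `C[C@H](NC(=O)CN(c1nc(Cl)nc2[nH]cnc12)C1CC1)C(=O)OCc1ccccc1`: 64.3%
Compound 2 `O=C(CN(c1ncnc2c1ncn2C1CCCCO1)C1CC1)NCC(=O)OCc1ccccc1`: 40.4%
Compound 3 `CC[C@H](C)[C@H](NC(=O)CN(c1nc(Cl)nc2[nH]cnc12)C1CC1)C(=O)O`: 36%

In a functional assay on the whole organism (Tail, strain ICR) with Mus musculus as the target, in the tail flick test, with a stated time of 60 min, at a dose of 25 umol/kg by the oral route (on this read-out higher numbers stand for a stronger effect at the one dose given and lower numbers for a weaker effect), compound 1 gives 64.3%, the highest of the three numbers. Compound 2 stands beyond the scatter below it, and compound 3 further still, also beyond the scatter. Compound 4 `C[C@@H](O)[C@H](NC(=O)CN(c1nc(Cl)nc2[nH]cnc12)C1CC1)C(=O)OCc1ccccc1` has not been measured in this assay. It differs from compound 1 in one place: 1-hydroxyethyl in place of methyl on a saturated chain carbon bound to an amide-type nitrogen and a carbonyl carbon. For the measured compounds named here, no measured pair shows the effect of this change, so no step of known size guides the expectation. A step from compound 1 to compound 4 of modest size, downward or none beyond the scatter, is expected here. For compound 4 in this assay the estimate is 50%, within a range from 25% to 75%, which means an expected step of a number 14.3 percentage points lower from compound 1 to compound 4 (beyond the scatter).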

Compound 4, a percentage reported as activity, at one dose (the size of the read-out at that dose, not a potency): 29.7%
Estimate against measurement, compound 4: 20.3 percentage points above; the measured number falls inside the stated range.
By their numbers in this assay, from the lowest: compounds 4, 3 and 2 (each within the scatter of the next, the first and the last beyond it); then compound 1.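

In this assay, 1-hydroxyethyl in place of methyl on a saturated chain carbon bound to an amide-type nitrogen and a carbonyl carbon gives a large step: a number 34.6 percentage points lower from compound 1 to compound 4 (beyond the scatter). This is the first single change shown at this position, and it shows that the read-out at this dose depends on the group placed there. Nothing measured here bears on what lies behind the step. The compounds shown leave open whether the step follows the hydroxyl or the added carbon; ethyl or hydroxymethyl at this place would separate the two.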